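The source may report more compounds than this note shows. Statements on the series, on what has been measured and on what is new or still open speak of the compounds shown alone.

Measured so far in a physicochemical assay for permeability, using PAMPA, at pH 4; a higher number here means that the compound crosses the layer faster, a lower number that the compound crosses the layer more slowly:
compound 1 `Cc1ccc2c(NCc3ccco3)nc(NC(C)C)nc2c1`, which gives 67.2 10^-6 cm/s
compound 2 `Cc1ccc2nc(NC(C)C)nc(NCc3ccco3)c2c1`, which gives 67.2 10^-6 cm/s
compound 3 `COc1ccc2c(NCc3ccco3)nc(NC(C)C)nc2c1`, which gives 59.2 10^-6 cm/s

Compound 3 differs from compound 1 by methoxy in place of methyl on an aromatic carbon, and that change made a step of a 1.1-fold lower number from compound 1 to compound 3 (0.06 log units; within the scatter). Compound 2 has the same atoms as compound 1, joined differently; the difference between the two cores is not broken down here. In this assay compound 2 stands level with compound 1 at the digits printed, the two together giving the highest of the three numbers, with compound 3 close behind and all three within the usual scatter of one another.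

Compound 4 `COc1ccc2nc(NC(C)C)nc(NCc3ccco3)c2c1` is not yet measured. It differs from compound 2 by methoxy in place of methyl on an aromatic carbon, the same change as from compound 1 to compound 3, placed in the same words. For the measured compounds named here, only that one measured pair is available for this change. Going by the values given here, the step in this assay from compound 2 to compound 4 is therefore expected to be about a 1.1-fold lower number from compound 2 to compound 4 (0.05 log units; within the scatter), resting on the single earlier step of a 1.1-fold lower number from compound 1 to compound 3 (0.06 log units; within the scatter). On that basis compound 4 is estimated to give 60 10^-6 cm/s, expected to fall between 40 10^-6 cm/s and 90 10^-6 cm/s.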

Compound 4, apparent permeability: 80.2 10^-6 cm/s
The estimate for compound 4 lay 1.3-fold (0.13 log units) below the measured number; measured number inside the range.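

In this assay, for the compounds shown here, the new step of a 1.2-fold higher number from compound 2 to compound 4 (0.08 log units; within the scatter) and the earlier step of a 1.1-fold lower number from compound 1 to compound 3 (0.06 log units; within the scatter) both lie within the scatter, so methoxy in place of methyl on an aromatic carbon gives no step on either core that can be told apart from repeat measurement. The two cores agree only in this sense: the change carries from one to the other without a readable effect, but two pairs set no direction for it and say nothing about a third core or any other read-out. Nothing available here bears on why these steps are small.

Still open, as far as these compounds go, is whether a group of a different kind on that same aromatic carbon, such as a carboxylic acid, a primary amine or a longer alkoxy chain, would move the number beyond the scatter. Also open, from the compounds shown here alone, is whether such a group would behave alike on both cores.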